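From Lactam Ether to Piperidinyl Ether on a Cathepsin S Core

The source may hold more compounds than are shown below. What is called first, only, known or untested is meant among the compounds shown, and "the series" means these compounds.

Within the data shown here, compound 3 `Cn1cnc2c(C#N)nc(-c3ccc(OCCN4CCCC4=O)c(C(F)(F)F)c3)cc21` gives 7.8 nM in an assay on isolated protein for inhibition of cathepsin S (Homo sapiens), read by fluorescence (on this read-out lower numbers stand for stronger inhibition and higher numbers for weaker inhibition), the lowest of the three numbers measured so far. Compound 1 `CCOc1ccc(-c2cc3c(ncn3C)c(C#N)n2)cc1C(F)(F)F` gives 40 nM in this assay, and compound 2 `Cn1cnc2c(C#N)nc(-c3ccc(CCO)c(C(F)(F)F)c3)cc21` gives 71 nM; the step of a 1.8-fold higher number from compound 1 to compound 2 (0.25 log units; within the scatter) stays within the scatter. The steps of a 5.1-fold lower number from compound 1 to compound 3 (0.71 log units; beyond the scatter) and a 9.1-fold lower number from compound 2 to compound 3 (0.96 log units; beyond the scatter) both lie beyond the scatter. Compound 4 `Cn1cnc2c(C#N)nc(-c3ccc(OC4CCNCC4)c(C(F)(F)F)c3)cc21` differs from compound 3 in one place: piperidin-4-yl in place of 2-(2-oxopyrrolidin-1-yl)ethyl on an oxygen on an aromatic ring. The steps from compound 1 and from compound 2 to compound 3 bear on this change. Each of them sets the ether substituent of compound 3 against a smaller group; compound 4 carries a group not seen among the measured compounds, so those steps only frame a range. A step of a 2.6-fold higher number from compound 3 to compound 4 (0.41 log units; beyond the scatter) toward a higher number is therefore expected, smaller than the gain seen in a 5.1-fold lower number from compound 1 to compound 3 (0.71 log units; beyond the scatter). Compound 4 is estimated at 20 nM in this assay, with a range from 6 nM to 70 nM.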

Compound 4, half-maximal inhibitory concentration: 316 nM
Compound 4: the middle estimate sits 16-fold (1.20 log units) below what was measured; measured number above the stated range.
By their numbers in this assay, from the lowest: compound 3; then compounds 1 and 2 (each within the scatter of the next); then compound 4.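

In this assay, the step of a 41-fold higher number from compound 3 to compound 4 (1.61 log units; beyond the scatter) shows that the gain of compound 3 belongs to its particular ether substituent and not to any larger ring-bearing group on this oxygen. The steps of a 7.9-fold higher number from compound 1 to compound 4 (0.90 log units; beyond the scatter) and a 4.5-fold higher number from compound 2 to compound 4 (0.65 log units; beyond the scatter) add that piperidin-4-yl also falls behind the smaller groups, so these are the only changes among those shown at this place that raise the number beyond the scatter. Nothing available here accounts for this loss.

Because the step from compound 3 to compound 4 replaces both the ring and the ethyl link, the compounds shown do not separate their contributions. A 2-(piperidin-4-yl)ethyl group, a 1-methylpiperidin-4-yl group or a 2-oxopiperidin-4-yl group on the same oxygen would each isolate one part of that change.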